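Swapping Bromo for Chloro on a Fused Aromatic Ring

This account rests on a few compounds, and the source may have more. Where it says the series, first, only, none or still open, it means among the compounds named here.

compound 1 `COc1ccc(C2=NN(C3=NC(=O)/C(=C4\C(=O)Nc5ccc(Cl)cc54)S3)C(c3ccc(OC)cc3)C2)cc1` — 280 nM
compound 2 `COc1ccc(C2=NN(C3=NC(=O)/C(=C4\C(=O)Nc5ccccc54)S3)C(c3ccc(Cl)cc3)C2)cc1` — 86600 nM
compound 3 `COc1ccc(C2=NN(C3=NC(=O)/C(=C4\C(=O)Nc5ccc(Br)cc54)S3)C(c3ccc(Cl)cc3)C2)cc1` — 190 nM

In a functional assay on cells (Leukemia cell, Homo sapiens) for cytotoxicity, read by sulforhodamine B assay, with a stated time of 48 h (on this read-out higher numbers stand for weaker inhibition of growth and lower numbers for stronger inhibition of growth), compound 3 gives the lowest number of the three, though compound 1 lies within the scatter of it; only compound 2 stands far off. Compound 4 `COc1ccc(C2=NN(C3=NC(=O)/C(=C4\C(=O)Nc5ccc(Cl)cc54)S3)C(c3ccc(Cl)cc3)C2)cc1` differs from compound 3 by chloro in place of bromo on an aromatic carbon. Within the data shown here, the one step that bears on this place is a 460-fold lower number from compound 2 to compound 3 (2.66 log units; beyond the scatter), where a halogen entered in place of hydrogen. Compound 1 already carries chloro at this place, and its number sits close to that of compound 3. Both observations suggest a halogen here goes with low numbers, and nothing separates chloro from bromo. The expected step is therefore a 1.2-fold higher number from compound 3 to compound 4 (0.08 log units; within the scatter), within the scatter. Compound 4 is estimated at 230 nM, in a range from 100 nM to 550 nM.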

Compound 4, concentration for 50% growth inhibition: 270 nM
The estimate for compound 4 lay 1.2-fold (0.07 log units) below the measured number; measured number inside the range.
By their numbers in this assay, from the lowest: compounds 3, 4 and 1 (each within the scatter of the next); then compound 2.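

In this assay, chloro and bromo at this place cannot be told apart, with a 1.4-fold higher number from compound 3 to compound 4 (0.15 log units; within the scatter). Chloro also gives a large step of its own, a 320-fold lower number from compound 2 to compound 4 (2.51 log units; beyond the scatter), so the link to a low number is not confined to bromo, and at a different place on the shared core, chloro in place of methoxy gives a 1.0-fold lower number from compound 1 to compound 4 (0.02 log units; within the scatter). Nothing measured here explains why a halogen at this place goes with such low numbers. As far as these compounds go, whether fluoro, an amine or a carboxylic acid at this place would also give a low number remains open.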